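The source may report more compounds than this note shows. Statements on the series, on what has been measured and on what is new or still open speak of the compounds shown alone.

Working notes on the chlorinated purine series.

The series rests on three measured members. Compound 1 `ClCc1ccc(Cn2cnc3c(Cl)ncnc32)cc1` carries a para-substituted benzyl arm on the shared core and, in a functional assay on OVCAR-5 cells (Homo sapiens) for cytotoxicity, read by sulforhodamine B assay, with a stated time of 48 h (on this read-out lower numbers stand for stronger inhibition of growth and higher numbers for weaker inhibition of growth), compound 1 gives 9230 nM. Compound 2 `ClCc1cccc(Cn2cnc3c(Cl)nc(Cl)nc32)c1` has its benzyl arm substituted in the meta pattern and two chloro groups on the core; in this assay compound 2 gives 20400 nM. Compound 3 `ClCc1ccccc1Cn1cnc2ncnc(Cl)c21` has the ortho pattern, and in this assay compound 3 gives 7240 nM.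

Among these three numbers compound 1 holds the second highest. The number for compound 3 is close to that of compound 1 and the gap between the two lies within the usual scatter, so no order between them is claimed. Compound 2 gives a higher number than compound 1, and that gap lies beyond the scatter.

Compound 4 `ClCc1ccc(Cn2cnc3c(Cl)nc(Cl)nc32)cc1` has not been measured. It differs from compound 1 by chloro in place of hydrogen on an aromatic carbon. Within the data shown here, no measured pair that differs only in this way is available, so the step is not anchored. Compound 2, which also carries the second chloro group, sits at the weaker end of the measured set, although it differs from compound 1 in a second place as well. Against that background a small step from compound 1 to compound 4 toward a higher number, a 1.4-fold higher number from compound 1 to compound 4 (0.15 log units; within the scatter), is expected, and it may not clear the scatter. Compound 4 is estimated at 13000 nM, with a plausible range from 5500 nM to 32000 nM.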

Compound 4, concentration for total growth inhibition: 34700 nM
Beside the measured number, compound 4's estimate is 2.7-fold (0.43 log units) below it; the measured number lies above the stated range.
By their numbers in this assay, from the lowest: compounds 3 and 1 (each within the scatter of the next); then compounds 2 and 4 (each within the scatter of the next).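

Working from the single-place pair, in this assay the step is a 3.8-fold higher number from compound 1 to compound 4 (0.58 log units; beyond the scatter) and it moves toward weaker inhibition of growth, beyond the usual scatter. Among these compounds, this is the first measured reading of chloro in place of hydrogen on the aromatic carbon between two ring nitrogen atoms, since compound 2 also carries the second chloro group but differs from compound 1 in a second place as well. With the para-substituted benzyl arm held the same in compound 1 and compound 4, the change in the number can be tied to this one position on the shared core, although no measurement at hand accounts for its size.

Whether the step carries over to the benzyl arm patterns of compound 2 and compound 3 stays open, as the compounds shown offer no matching pair for either arm. Also open, on these data alone, is how the number would respond to an amine, a methoxy group or a fluoro group on this same carbon, so the reading so far belongs to chloro alone.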